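Fluoro for methoxy on the indole of compound 2

The source may hold more compounds than are shown below. What is called first, only, known or untested is meant among the compounds shown, and "the series" means these compounds.

- compound 1 `N#C/C(=C\c1cn(Cc2ccc(Cl)cc2)c2ccccc12)C(=O)c1c[nH]c2cc(F)ccc12`: > 50000 nM (a limit)
- compound 2 `COc1ccc(Cn2cc(/C=C(\C#N)C(=O)c3c[nH]c4cc(OC)ccc34)c3ccccc32)cc1`: > 50000 nM (a limit)

Both entries come from a functional assay on PC-3 cells (Homo sapiens) for cytotoxicity, read by WST assay, with a stated time of 24 h; on this read-out higher numbers stand for weaker inhibition and lower numbers for stronger inhibition. Compound 2 stands at > 50000 nM, which is a limit of the assay and not a number. Going by the values given here, the series so far reads (the limit of > 50000 nM in this assay, at which 2 of the 2 values shown sit), so no measured number fixes the place of compound 2, and no step between measured compounds is available.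

The next compound is compound 3 `COc1ccc(Cn2cc(/C=C(\C#N)C(=O)c3c[nH]c4cc(F)ccc34)c3ccccc32)cc1`. It carries fluoro in place of methoxy on an aromatic carbon, with 6-methoxy-1H-indol-3-yl becoming 6-fluoro-1H-indol-3-yl: fluoro in place of methoxy on an aromatic carbon.

Among the compounds with values here, with no measured step to draw on, the expectation rests only on this single exchange and on the limit reached by both measured compounds. No change beyond the scatter is expected in this assay, and no direction is favoured. On that basis, a number no higher from compound 2 to compound 3 (the limit leaves the size open) is the estimated step. Compound 3 is expected at 50000 nM, with an estimated range from 15000 nM to 100000 nM. A further report of only a limit is the likeliest outcome.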

Compound 3, half-maximal inhibitory concentration: > 50000 nM
Compound 3: only a limit was reported; the forecaster's own chance of this, stated with the estimate: 70%; the middle value lies on the limit itself.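

In this assay compound 3 gives > 50000 nM as a limit and not a number. Going by these compounds alone, compound 1 and compound 2 also stand only as limits, so no step to compound 3 can be read from either. The compounds shown leave open whether 6-fluoro-1H-indol-3-yl and 6-methoxy-1H-indol-3-yl differ at all on this read-out.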